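The compounds below may be only part of what the source reports. "The series", "measured", "known", "first", "only" and "open" are said of these compounds alone.

Measured compounds and their values in a functional assay on the whole organism with Rattus norvegicus as the target, at a dose of 40 mg/kg by the intraperitoneal route; a lower number here means less inhibition, a higher number more inhibition at the dose given (going by the name of the read-out):
compound 1 `Cc1nc2c(OCc3ccccc3)cccn2c1CN`, 46%
compound 2 `CNC(=O)Nc1c(C)nc2c(OCc3ccccc3)cccn12`, 22%
compound 3 `CNc1c(C)nc2c(OCc3ccccc3)cccn12`, 55%

Compound 3 carries the largest number of the three, but compound 1 sits within the scatter of it, so the two cannot be told apart; only compound 2 stands clearly apart, with a number 33 percentage points higher from compound 2 to compound 3 (beyond the scatter) between them. Compound 4 `Cc1nc2c(OCc3ccccc3)cccn2c1NC(C)C` differs from compound 3 in one place: isopropyl in place of methyl on a nitrogen on an aromatic ring. Going by the values given here, the only measured step at the same place is the one from compound 2 to compound 3, where a number 33 percentage points higher from compound 2 to compound 3 (beyond the scatter) accompanied the exchange of methylcarbamoyl for methyl on a nitrogen on an aromatic ring. That step swapped a much larger and more functionalised group for a small one; the step to compound 4 enlarges the small alkyl group by two carbons and changes no donors or acceptors. Nothing in the three compounds shows how such a growth of the alkyl group on this nitrogen plays out, so in this assay a step of a number 5 percentage points lower from compound 3 to compound 4 (within the scatter) is expected, that is, none beyond the scatter. Compound 4 is therefore estimated at 50%, with a range from 30% to 70%.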

Compound 4, a percentage reported as inhibition, in the whole organism at one dose (the size of the read-out at that dose, not a potency): 18%
Compound 4: the middle estimate sits 32 percentage points above what was measured; measured number outside the range, below it.
By their numbers in this assay, from the lowest: compounds 4 and 2 (each within the scatter of the next); then compounds 1 and 3 (each within the scatter of the next).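

In this assay, enlarging the alkyl group on this nitrogen, with no hydrogen-bond donor or acceptor entering or leaving, gave a number 37 percentage points lower from compound 3 to compound 4 (beyond the scatter) and so shows that this position is sensitive to the alkyl group alone. The isopropylamino group also stands clearly apart from aminomethyl, with a number 28 percentage points lower from compound 1 to compound 4 (beyond the scatter) on the aromatic carbon, whereas the exchange of methylcarbamoyl for isopropyl gave a number 4 percentage points lower from compound 2 to compound 4 (within the scatter) and leaves those two compounds indistinguishable. No measurement available here explains why the larger alkyl group goes with the lower number.

Going by these compounds, it remains open whether ethyl on this nitrogen would fall nearer to methyl or to isopropyl. The behaviour of the unsubstituted amine, a longer chain such as butyl, or a ring such as cyclopropyl at this position is also unresolved.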